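The source may hold more compounds than are shown below. What is called first, only, known or untested is meant among the compounds shown, and "the series" means these compounds.

Measured compounds:
- compound 1 `CO[C@H]1CC[C@@H](Nc2cc(NCc3cnccc3C(F)(F)F)ncc2C#N)CC1`: 1%
- compound 2 `N#Cc1cnc(NCc2cnccc2C(F)(F)F)cc1N[C@H]1CC[C@@H](c2nc[nH]n2)CC1`: 29%

In an ADME assay on S9 fraction from liver (Rattus norvegicus) for metabolic stability, with a stated time of 1 h (a lower number here means that less of the compound is left, a higher number that more of the compound is left), compound 2 holds the highest number of the two, at 29%, while compound 1 gives 1%. The next compound, compound 3 `N#Cc1cnc(NCc2cnccc2C(F)(F)F)cc1N[C@H]1CC[C@@H](n2cncn2)CC1`, has the same atoms as compound 2, joined differently: 1H-1,2,4-triazol-1-yl in place of 1H-1,2,4-triazol-3-yl on a saturated ring carbon. Its 1H-1,2,4-triazol-1-yl stands in place of 1H-1,2,4-triazol-3-yl on a saturated ring carbon. Going by the values given here, only one measured step bears on this, and only indirectly: a number 28 percentage points higher from compound 1 to compound 2 (beyond the scatter), a modest rise beyond the scatter on replacing methoxy with the 1H-1,2,4-triazol-3-yl group at that carbon. Among the compounds with values here, no measured step compares the two triazole attachments, so no change beyond the scatter is expected, though with wide uncertainty. The expected step is a number 1 percentage points higher from compound 2 to compound 3 (within the scatter). For compound 3, the estimate is 30%, with an expected range from 10% to 55%.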

Compound 3, percent of the compound remaining: 44%
Beside the measured number, compound 3's estimate is 14 percentage points below it; the measured number falls inside the stated range.
By their numbers in this assay, from the lowest: compound 1; then compound 2; then compound 3.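

In this assay, the way the triazole is attached at this saturated ring carbon proves to matter, not just its atoms: the step is a number 15 percentage points higher from compound 2 to compound 3 (beyond the scatter). Measured against methoxy at the same carbon, the 1H-1,2,4-triazol-1-yl group gives a number 43 percentage points higher from compound 1 to compound 3 (beyond the scatter), which is a large step. The group that enters has 0 hydrogen-bond donors and the group that leaves has 1, but two isomers cannot show whether that count matters, and nothing measured here explains the difference.

From the compounds shown here alone, it remains open what a carboxylic acid, an amine or a longer chain would give at this carbon. Going by these compounds, it is also open whether the order of the two triazole attachments would hold on any core other than the one shared here.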